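Methyl for chloro: a solubility note on compound 4

The compounds below may be only part of what the source reports. "The series", "measured", "known", "first", "only" and "open" are said of these compounds alone.

Compound 1 `CC(C)C(/C=C1\OC(=O)NC1=O)c1cc(Cl)c(-c2ccc3cccc(F)c3c2)[nH]c1=O`, compound 2 `CC(C)(/C=C1\OC(=O)NC1=O)c1ccc(-c2ccc3cccc(F)c3c2)[nH]c1=O` and compound 3 `O=C1NC(=O)/C(=C/C(c2ccc(-c3ccc4cccc(F)c4c3)[nH]c2=O)C2CC2)O1` share one core and differ only in the groups set around it. In a physicochemical assay for solubility, measured as kinetic solubility, at pH 2 (a higher number here means a more soluble compound, a lower number a less soluble compound), compound 1 gives 3200 nM, compound 2 gives 1660 nM and compound 3 gives 3850 nM. Compound 1 stands second highest of the three numbers, yet its gap to compound 3 and its gap to compound 2 both lie within the usual scatter, so the three measured compounds read as a single level of solubility.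

Compound 4 `Cc1cc(C(/C=C2\OC(=O)NC2=O)C(C)C)c(=O)[nH]c1-c1ccc2cccc(F)c2c1` departs from compound 1 in one place: methyl in place of chloro on an aromatic carbon. Among the compounds with values here, no measured pair shows this change, so its effect in this assay cannot be read from the series, and the three measured compounds give no lead on its direction. The step from compound 1 to compound 4 is expected to be a 1.1-fold lower number from compound 1 to compound 4 (0.03 log units; within the scatter), none beyond the scatter. Compound 4 is therefore estimated at 3000 nM, with a range from 1500 nM to 6000 nM.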

Compound 4, solubility: 39400 nM
For compound 4 the middle estimate is 13-fold (1.12 log units) below the measured one; measured number above the stated range.
By their numbers in this assay, from the lowest: compounds 2, 1 and 3 (each within the scatter of the next, the first and the last beyond it); then compound 4.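

Within the data shown here, this position, two atoms from the ring nitrogen, proves highly responsive: in this assay, methyl in place of chloro gives a 12-fold higher number from compound 1 to compound 4 (1.09 log units; beyond the scatter), whereas the earlier compounds offered no pair that isolated this aromatic carbon. Each group counts 1 heavy atom, and neither brings a ring, a hydrogen-bond donor or acceptor, or a net charge, so those counts do not register an exchange that produces a large step. Nothing measured in the series accounts for the step.

From the compounds shown here alone, with a single matched pair, it remains open whether the step belongs to methyl itself or to the departure of chloro. Ethyl, methoxy or an amine on this aromatic carbon of the core of compound 1 would show how far the step extends.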